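From Benzyloxycarbonyl to Phenethyloxycarbonyl at the Assay Limit

The source may hold more compounds than are shown below. What is called first, only, known or untested is meant among the compounds shown, and "the series" means these compounds.

Measured in a functional assay on SK-BR-3 cells (Homo sapiens) for antiproliferative activity, read by MTT assay, with a stated time of 72 h; a lower number here means a stronger inhibitor, a higher number a weaker inhibitor:
- compound 1 `C/C=C1/[C@H](O[C@@H]2O[C@H](CO)[C@@H](O)[C@H](O)[C@H]2O)OC=C(C(=O)OC)[C@H]1CC(=O)OCc1ccco1`: > 15000 nM
- compound 2 `C/C=C1/[C@H](O[C@@H]2O[C@H](CO)[C@@H](O)[C@H](O)[C@H]2O)OC=C(C(=O)OC)[C@H]1CC(=O)OCC`: > 15000 nM
- compound 3 `C/C=C1/[C@H](O[C@@H]2O[C@H](CO)[C@@H](O)[C@H](O)[C@H]2O)OC=C(C(=O)OC)[C@H]1CC(=O)OCc1ccccc1`: > 15000 nM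

Each of these values is a limit and not a number. The whole set shares one result, (the limit of > 15000 nM in this assay, at which 3 of the 3 values shown sit).

Compound 4 `C/C=C1/[C@H](O[C@@H]2O[C@H](CO)[C@@H](O)[C@H](O)[C@H]2O)OC=C(C(=O)OC)[C@H]1CC(=O)OCCc1ccccc1` differs from compound 3 by benzyl in place of phenyl on a saturated chain carbon bound to an oxygen next to a carbonyl group, which is benzyl in place of phenyl on a saturated chain carbon bound to an oxygen next to a carbonyl group.

The closest measured changes fall at this same place: a step that the two limits leave unreadable from compound 2 to compound 3 and a step that the two limits leave unreadable from compound 1 to compound 3. Among the compounds with values here, neither gives a size to carry over, so no step of known size or direction is expected in this assay, and another limit is the likeliest report.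

The expected change is a step that the limit leaves unreadable from compound 3 to compound 4.

For compound 4 the estimated value is 20000 nM, with an expected range of 10000 nM to 50000 nM.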

Compound 4, half-maximal inhibitory concentration: 11000 nM
Estimate against measurement, compound 4: 1.8-fold (0.26 log units) above; low and high end bracket the measured number.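

In this assay, within the data shown here, phenethyl is the first group at this place to give a number and not a limit, while the other compounds stay at the limit: (the limit of > 15000 nM in this assay, at which 3 of the 4 values shown sit). The data give an at least 1.3-fold lower number from compound 3 to compound 4 (0.13 log units; that floor lies within the scatter) and an at least 1.3-fold lower number from compound 2 to compound 4 (0.13 log units; that floor lies within the scatter) and an at least 1.3-fold lower number from compound 1 to compound 4 (0.13 log units; that floor lies within the scatter) as floors only. All three lie within the scatter, so no real gain over the benzyl, ethyl or furan-2-ylmethyl compounds is shown.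

The compounds shown leave open whether a longer chain, such as phenylpropyl, would give a lower number. They also leave open what an amine or a carboxylic acid on the phenyl ring would do.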